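Swapping the Piperazine Arm for a Triazole Ester

A few compounds are considered here, and "the series" means these few. Any claim that something is new, unique, unknown or untested is made for them only; others in the source may bear on it.

Measured so far:
Compound 1, `CN1CCN(Cc2nnc(-c3cc(S(N)(=O)=O)c(SCc4ccccc4)cc3Cl)o2)CC1`: 75000 nM
Compound 2, `NS(=O)(=O)c1cc(-c2nnc(CN3CCN(Cc4ccccc4)CC3)o2)c(Cl)cc1SCc1ccccc1`: 17000 nM
Compound 3, `NS(=O)(=O)c1cc(-c2nnc(CN3CCN(c4ccc(F)cc4)CC3)o2)c(Cl)cc1SCc1ccccc1`: 10000 nM

All three were tested in a functional assay on HeLa cells (Homo sapiens) for cytotoxicity, read by MTT assay, with a stated time of 72 h; a higher number here means a weaker inhibitor, a lower number a stronger inhibitor. Compound 1 gives the highest number of the three, so it is the weakest inhibitor here; compound 2 and compound 3 each give a lower number, and both of those steps lie beyond the scatter, while compound 2 and compound 3 cannot be separated from each other because a 1.7-fold lower number from compound 2 to compound 3 (0.23 log units; within the scatter).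

Compound 4, `CCOC(=O)c1cn(Cc2nnc(-c3cc(S(N)(=O)=O)c(SCc4ccccc4)cc3Cl)o2)nn1`, has not yet been measured. It differs from compound 1 in one place: 4-(ethoxycarbonyl)-1H-1,2,3-triazol-1-yl in place of 4-methylpiperazin-1-yl on a saturated chain carbon bound to an aromatic carbon. The measured steps change only the substituents on the piperazine while keeping that ring: a 4.4-fold lower number from compound 1 to compound 2 (0.64 log units; beyond the scatter) and a 7.5-fold lower number from compound 1 to compound 3 (0.88 log units; beyond the scatter). Neither step replaces the whole ring, so they bear on compound 4 only loosely; they show that this part of the shared core tolerates change and that moving away from the simple methylpiperazine has so far lowered the number modestly.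

On that basis compound 4 is expected to give a number somewhat lower than compound 1, with wide uncertainty: the estimated step is a 1.9-fold lower number from compound 1 to compound 4 (0.27 log units; within the scatter). The estimate for compound 4 is 40000 nM, expected to fall between 15000 nM and 100000 nM.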

Compound 4, half-maximal inhibitory concentration: 122000 nM
For compound 4 the middle estimate is 3.1-fold (0.48 log units) below the measured one, and the stated range ends below it.
By their numbers in this assay, from the lowest: compounds 3 and 2 (each within the scatter of the next); then compounds 1 and 4 (each within the scatter of the next).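

Replacing the whole 4-methylpiperazin-1-yl group with 4-(ethoxycarbonyl)-1H-1,2,3-triazol-1-yl, on the saturated chain carbon bound to an aromatic carbon, gives a 1.6-fold higher number from compound 1 to compound 4 (0.21 log units; within the scatter) in this assay, so compound 1 and compound 4 cannot be told apart in this assay. The earlier steps shown here kept the piperazine and changed only the group on its nitrogen, giving a 4.4-fold lower number from compound 1 to compound 2 (0.64 log units; beyond the scatter) and a 7.5-fold lower number from compound 1 to compound 3 (0.88 log units; beyond the scatter), whereas this step shows that a very different group can stand here with no change that can be read: a six-membered non-aromatic ring gives way to a five-membered aromatic one, and the group grows from 7 to 10 heavy atoms and from 2 to 5 hydrogen-bond acceptors. No measured evidence is available to explain this result.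

The compounds shown leave open whether the triazole ring and the ethyl ester each matter on their own, a question that a triazole carrying a carboxylic acid or a primary amide in place of the ethoxycarbonyl group could address. They also leave open whether a phenyl group on the triazole would lower the number, as the benzyl and 4-fluorophenyl groups did on the piperazine.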